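The source may report more compounds than this note shows. Statements on the series, on what has been measured and on what is new or still open speak of the compounds shown alone.

Measured so far:
Compound 1, `O=C(O)CNc1cccc(CNc2cc(C(F)(F)F)cc3[nH]ncc23)c1`: 65%
Compound 2, `O=C(O)c1cccc(CNc2cc(C(F)(F)F)cc3[nH]ncc23)c1`: 94%

Both were tested in an assay for inhibition of Tryptophan 2,3-dioxygenase (Homo sapiens), with stated times of 10 min and 60 min, tested at 100 uM; a higher number here means a stronger effect of the compound at the concentration tested, a lower number a weaker effect. For the measured compounds named here, compound 2 stands highest of the two numbers, and its only neighbour is compound 1, which lies a number 29 percentage points higher from compound 1 to compound 2 (beyond the scatter). Compound 3, `Nc1cccc(CNc2cc(C(F)(F)F)cc3[nH]ncc23)c1`, differs from compound 2 in one place: amino in place of carboxy on an aromatic carbon. Going by the values given here, the single step that bears on this change runs from compound 1 to compound 2, where the carboxy group was the higher of the two. Removing the carboxy altogether in compound 3 is therefore expected to cost activity, a step of about a number 39 percentage points lower from compound 2 to compound 3 (beyond the scatter) in this assay. The expected value for compound 3 is 55%, within a range of 25% to 85%.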

Compound 3, a percentage reported as inhibition, at one concentration (the size of the read-out at that concentration, not a potency): 89%
Estimate against measurement, compound 3: 34 percentage points below, and the stated range ends below it.
By their numbers in this assay, from the lowest: compound 1; then compounds 3 and 2 (each within the scatter of the next).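

Carboxy and amino, which share no atoms, are interchangeable at this ring position within the precision of the assay: the swap gives a number 5 percentage points lower from compound 2 to compound 3 (within the scatter). The lower number of compound 1 therefore goes with the carboxymethyl on the nitrogen, not with the absence of carboxy, since replacing that carboxymethyl with hydrogen gives a number 24 percentage points higher from compound 1 to compound 3 (beyond the scatter). Nothing available explains either step. Going by these compounds, it remains open whether plain hydrogen, a hydroxyl or a nitrile at this position would hold the number, and whether a methyl on the nitrogen would lower it as carboxymethyl does. These single-concentration read-outs also leave the potencies of compound 2 and compound 3 unresolved.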